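Swapping the amide end of a weakly cytotoxic pyrazolopyridine

The source may report more compounds than this note shows. Statements on the series, on what has been measured and on what is new or still open speak of the compounds shown alone.

Measured so far:
compound 1 `CCNC(=O)Cn1nc(N)c2c(C(F)(F)F)cc(-c3ccccc3)nc21` gives 18800 nM in a functional assay on A549 cells (Homo sapiens) for cytotoxicity, read by MTT assay, with a stated time of 24 h; on this read-out higher numbers stand for weaker inhibition and lower numbers for stronger inhibition
compound 2 `Nc1nn(CC(=O)NCc2ccccc2)c2nc(-c3ccccc3)cc(C(F)(F)F)c12` gives 17300 nM in this assay

Compound 1 and compound 2 share one core and differ only at the amide end of the side chain. In this assay, among the compounds with values here, they cannot be told apart: the step of a 1.1-fold lower number from compound 1 to compound 2 (0.04 log units; within the scatter) lies within the scatter, so compound 1 stands level with the only other compound measured.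

Compound 3 `CN1CCN(C(=O)Cn2nc(N)c3c(C(F)(F)F)cc(-c4ccccc4)nc32)CC1` is not yet measured. It differs from compound 1 in 4-methylpiperazin-1-yl in place of ethylamino on a carbonyl carbon. Within the data shown here, the single known step also changed the group on the amide nitrogen, and it changed nothing beyond the scatter; this is thin evidence, and a ring in place of a short chain is a different kind of change, yet it is all there is. The step of a 1.0-fold lower number from compound 1 to compound 3 (0.02 log units; within the scatter) is therefore expected to stay within the scatter. Compound 3 is estimated at 18000 nM, with a range from 6000 nM to 50000 nM.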

Compound 3, half-maximal inhibitory concentration: 18400 nM
Compound 3: middle estimate off by 1.0-fold (0.01 log units), on the low side; low and high end bracket the measured number.
By their numbers in this assay, from the lowest: compounds 2, 3 and 1 (each within the scatter of the next).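

Replacing ethylamino on the carbonyl carbon with 4-methylpiperazin-1-yl trades a chain with one hydrogen-bond donor for a larger six-membered ring with none, yet the result in this assay is a 1.0-fold lower number from compound 1 to compound 3 (0.01 log units; within the scatter) and nothing more. Set against the benzylamino group of compound 2, the same ring gives a 1.1-fold higher number from compound 2 to compound 3 (0.03 log units; within the scatter) and so adds no separation, which shows that this end of the side chain can lose the amide hydrogen and gain a ring with no change beyond the scatter across these three compounds. No measurement shown here explains why the number stays put.

Going by these compounds, it remains open whether any group at this end can move the number beyond the scatter, such as a carboxylic acid in place of the amide or a morpholine ring in place of 4-methylpiperazin-1-yl. The trifluoromethyl and phenyl groups on the shared core are the same in all three compounds, so the effect of changing either one is also unknown.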